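A few compounds are considered here, and "the series" means these few. Any claim that something is new, unique, unknown or untested is made for them only; others in the source may bear on it.

Measured compounds:
compound 1 `CN(C)C(=O)c1cnc(C(=O)CCc2ccc(COc3ccccc3)cc2)o1` — 6.7 nM
compound 2 `NC(=O)c1ccc(-c2cnc(CCCc3ccc(-c4ccccc4)cc3)o2)nc1` — 30000 nM
compound 3 `CN(C)C(=O)c1cnc(C(=O)CCc2ccc(-c3ccccc3)cc2)o1` — 3 nM

Among the compounds with values here, in an assay for inhibition of Fatty-acid amide hydrolase 1 (Rattus norvegicus) (a lower number here means a stronger inhibitor, a higher number a weaker inhibitor), compound 1 stands second highest of the three numbers; its nearest neighbour is compound 3, which differs by a 2.2-fold lower number from compound 1 to compound 3 (0.35 log units; beyond the scatter), and the furthest is compound 2, whose value lies far above, though the two structures differ in several places and no single step is drawn between them.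

The unmeasured compound 4 `O=C(CCc1ccc(COc2ccccc2)cc1)c1ncc(I)o1` differs from compound 1 at the five-membered ring of the shared core: iodo in place of dimethylcarbamoyl on an aromatic carbon. Within the data shown here, none of the measured steps bears directly on this change; the only drawn step, phenyl in place of phenoxymethyl, touches the other end of the molecule and was modest. The ring substituent is therefore untested in this set, and any expectation rests on the retained core and chain, which compound 1 shows to support strong inhibition in this assay.

For compound 4 a value of 20 nM is estimated, with a range of 5 nM to 80 nM. Among the measured compounds shown here, the step implied by this estimate, a 3.0-fold higher number from compound 1 to compound 4 (0.47 log units; beyond the scatter), is expected to be a modest weakening, with no measured step to confirm it.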

Compound 4, inhibition constant: 4 nM
The estimate for compound 4 lay 5.0-fold (0.70 log units) above the measured number; the whole stated range lies above it.
By their numbers in this assay, from the lowest: compounds 3, 4 and 1 (each within the scatter of the next, the first and the last beyond it); then compound 2.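

In this assay, iodo in place of dimethylcarbamoyl on the aromatic carbon next to the ring oxygen gives a 1.7-fold lower number from compound 1 to compound 4 (0.22 log units; within the scatter), so compound 1 and compound 4 cannot be told apart. Strong inhibition on this core therefore does not depend on the dimethylcarbamoyl group: a single iodine atom stands in for 5 heavy atoms and the group's hydrogen-bond acceptor, and the reading stays within the scatter. Nothing available explains why these two different groups read alike.

Still open, on these data alone, is whether a carboxylic acid, a primary amine or a bare hydrogen on this carbon would read the same in this assay. Also open, as far as these compounds go, is whether iodo holds up when phenyl replaces phenoxymethyl at the other end of the molecule, as in compound 3.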